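A few compounds are considered here, and "the series" means these few. Any claim that something is new, unique, unknown or untested is made for them only; others in the source may bear on it.

Of the compounds shown here, two of one shared core have been measured in a functional assay on CCRF-CEM cells (Homo sapiens) for antiproliferative activity, read by MTT assay, with a stated time of 48 h, tested at 100 uM; on this read-out higher numbers stand for a weaker effect at the one concentration tested and lower numbers for a stronger effect. Compound 1 `OC(CCn1nc2c(Br)c(Br)c(Br)c(Br)c2n1)c1cccc(Br)c1` gives 0% in this assay, and compound 2 `OC(CCn1nc2c(Br)c(Br)c(Br)c(Br)c2n1)c1ccc(F)cc1` gives 0%. Within the data shown here, the only measured step, no change at the digits printed from compound 1 to compound 2 (within the scatter), shows that swapping one aryl group for another on the saturated chain carbon left the read-out unmoved. Compound 2 therefore stands level with compound 1 on the numbers shown, with no difference beyond the scatter between them.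

Compound 3 `COc1cccc(C(O)CCn2nc3c(Br)c(Br)c(Br)c(Br)c3n2)c1` differs from compound 2 by the change (3-methoxyphenyl in place of 4-fluorophenyl on a saturated chain carbon bound to an oxygen on a saturated carbon and a saturated chain carbon). Among the measured compounds shown here, the one step that bears on this, the aryl swap in no change at the digits printed from compound 1 to compound 2 (within the scatter), was flat, so another aryl swap at the same place is expected to give no step beyond the scatter. The estimate for compound 3 is 0%, between 0% and 15%, which means an expected step of no change at the digits printed from compound 2 to compound 3 (within the scatter) in this assay.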

Compound 3, a percentage reported as activity, at one concentration (the size of the read-out at that concentration, not a potency): 2%
Beside the measured number, compound 3's estimate is 2 percentage points below it; measured number inside the range.
By their numbers in this assay, from the lowest: compounds 1, 2 and 3 (each within the scatter of the next).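

In this assay the number is read as a number 2 percentage points higher from compound 2 to compound 3 (within the scatter) and a number 2 percentage points higher from compound 1 to compound 3 (within the scatter) at this place, so neither step lies beyond the scatter. This extends the flat picture from two halogen-bearing aryl groups to a 3-methoxyphenyl group, which carries a hydrogen-bond acceptor where the 4-fluorophenyl group has none, and that difference leaves no mark on this read-out. Nothing measured here offers an explanation for this flat result.

From the compounds shown here alone, with only these three aryl groups, it remains open whether any group on this saturated chain carbon can shift the read-out beyond the scatter. A ring bearing an amine or a carboxylic acid, or a longer chain between the hydroxyl-bearing carbon and the shared core, would test this.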